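The source may hold more compounds than are shown below. What is called first, only, known or untested is meant among the compounds shown, and "the series" means these compounds.

Measured compounds:
- compound 1, `O=C(Nc1nc(-c2cccc(OC3CCCC3)c2)cs1)c1ccc([N+](=O)[O-])o1`, an ADME assay on Vero cells (Chlorocebus sabaeus) for cytotoxicity, read by MTT assay, with a stated time of 72 h; a higher number here means a weaker inhibitor, a lower number a stronger inhibitor: 81100 nM
- compound 2, `CC(C)(C)OC(=O)Nc1cccc(-c2csc(NC(=O)c3ccc([N+](=O)[O-])o3)n2)c1`, this assay: "not determined" (no result reported)

Compound 2 has no number of its own in this assay; the only figure in the series is that of compound 1, which gives 81100 nM there. Going by the values given here, compound 2 therefore stands nowhere on the scale, and no step between measured compounds can be drawn from it.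

Compound 3, `O=C(Nc1cccc(-c2csc(NC(=O)c3ccc([N+](=O)[O-])o3)n2)c1)c1ccccc1`, differs from compound 2 by phenyl in place of tert-butoxy on a carbonyl carbon, or tert-butoxycarbonyl to benzoyl. Among the compounds with values here, with no measured step, no direction for this change can be read from the data; a shift within the scatter is as plausible as a shift beyond it, and the weak cytotoxicity seen for compound 1 is the only anchor.

Compound 3 is expected to give about 60000 nM in this assay, estimated between 15000 nM and 200000 nM.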

Compound 3, half-maximal inhibitory concentration: 50200 nM
Estimate against measurement, compound 3: 1.2-fold (0.08 log units) above, within the range that was stated.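

In this assay, going by these compounds alone, the exchange of cyclopentyloxy for benzamido on an aromatic carbon gives a 1.6-fold lower number from compound 1 to compound 3 (0.21 log units; within the scatter) and so stays within the scatter; this is the first readable step, and at this place the two groups are not told apart by this read-out. The change from tert-butoxycarbonyl to benzoyl cannot be read, since compound 2 has no number in this assay and only compound 3 carries a value on that side. No measurement at hand bears on why the numbers for the two compounds lie so close.

On these data alone, whether a small amine, a carboxylic acid or a longer alkyl chain on the same aromatic carbon would still fall within the scatter of these two values remains open. So does the question of whether any group at this place can move the number beyond the scatter at all.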